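The source may report more compounds than this note shows. Statements on the series, on what has been measured and on what is new or still open speak of the compounds shown alone.

Compound 1, `Cc1cccc(-n2c(Cn3nc(C)cc3C)n[nH]c2=S)c1`, gives 13.2% in a functional assay on the whole organism (strain albino) for inhibition, with Rattus norvegicus as the target, read by paw edema, with a stated time of 1 h, at a dose of 100 mg/kg by the oral route; on this read-out higher numbers stand for more inhibition at the one dose given (going by the name of the read-out) and lower numbers for less inhibition.
Compound 2, `Cc1cc(C)n(Cc2n[nH]c(=S)n2-c2ccc([N+](=O)[O-])cc2)n1`, gives 16.6% in this assay.
Compound 3, `Cc1cc(C)n(Cc2nnc(Nc3ccc([N+](=O)[O-])cc3)s2)n1`, gives 37.5% in this assay.

Among these three numbers compound 3 stands highest in this assay. Its nearest neighbour is compound 2, whose number lies lower by a margin beyond the scatter, and compound 1 lies lower still, also beyond the scatter. For the measured compounds named here, compounds 1 and 2 share a core that differs from that of compound 3, so no single-change step between measured compounds is available to guide what follows.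

Compound 4, `Cc1cc(-c2ccc(Cl)cc2)n(Cc2nnc(Nc3ccc([N+](=O)[O-])cc3)s2)n1`, is built from compound 3 by the change (4-chlorophenyl in place of methyl on an aromatic carbon). Going by the values given here, nothing among the measured compounds shows how such a replacement moves the read-out in this assay, so the account can lean only on the value of compound 3 itself. The step from compound 3 to compound 4 is expected to be small, estimated at a number 0.5 percentage points higher from compound 3 to compound 4 (within the scatter), with no direction favoured beyond the scatter. For compound 4 the estimated value in this assay is therefore 38%, within a range from 22% to 55%.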

Compound 4, a percentage reported as inhibition, in the whole organism at one dose (the size of the read-out at that dose, not a potency): 32.8%
Compound 4: middle estimate off by 5.2 percentage points, on the high side, and the stated range covers the measured number.
By their numbers in this assay, from the lowest: compounds 1 and 2 (each within the scatter of the next); then compounds 4 and 3 (each within the scatter of the next).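

In this assay, for the compounds shown here, the change of methyl to 4-chlorophenyl on this aromatic carbon gives a number 4.7 percentage points lower from compound 3 to compound 4 (within the scatter), the first single-change step. The position next to the ring nitrogen therefore takes a much larger group, with an added six-membered aromatic ring, and the read-out at the one dose given does not separate the two compounds. No measured property bears on why the number holds across this change.

The compounds shown hold only methyl and 4-chlorophenyl at this place, so it stays open whether an amine, a carboxylic acid or a longer chain such as butyl would leave the number in the same range. Also open, going by these compounds, is what the chlorine contributes, since an unsubstituted phenyl does not appear among them, and what replacing the remaining ring methyl would do.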